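The compounds below may be only part of what the source reports. "The series", "measured", "known", "first", "only" and "open" are said of these compounds alone.

Measured so far:
- compound 1, `ClCc1ccc(Cn2cnc3c(Cl)ncnc32)cc1`: 1000 nM
- compound 2, `ClCc1ccccc1Cn1cnc2c(Cl)nc(Cl)nc21`: 150 nM

In a functional assay on LOX IMVI cells (Homo sapiens) for cytotoxicity, read by sulforhodamine B assay, with a stated time of 48 h (a higher number here means a weaker inhibitor of growth, a lower number a stronger inhibitor of growth), compound 2 gives the lowest of the two numbers; compound 1 sits well higher, and the gap between them lies beyond the scatter. For the measured compounds named here, compound 1 and compound 2 differ in more than one place, so no single-change step between measured compounds is available in this set.

The next compound, compound 3, `ClCc1ccccc1Cn1cnc2c(Cl)ncnc21`, takes off one of the two chloro groups of compound 2: hydrogen in place of chloro on an aromatic carbon. This leaves the chloromethyl-bearing benzyl group and the remaining chloro group of compound 2 untouched. Going by the values given here, with no measured single-change step to lean on, the direction of this change is open. Among the compounds with values here, the only hint is that compound 1, which also carries a single chloro on its core, gives the higher number of the two; but compound 1 also differs elsewhere, so this cannot be read as a step. A moderate rise in this assay is expected, of a size that may or may not clear the scatter, a 2.7-fold higher number from compound 2 to compound 3 (0.43 log units; beyond the scatter). Compound 3 is estimated at 400 nM, with a range from 150 nM to 1200 nM.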

Compound 3, concentration for 50% growth inhibition: 2130 nM
Estimate against measurement, compound 3: 5.3-fold (0.73 log units) below, outside the stated range (above it).
By their numbers in this assay, from the lowest: compound 2; then compound 1; then compound 3.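

In this assay, for the compounds shown here, the chloro group on the aromatic carbon between two ring nitrogen atoms proves to matter for growth inhibition: hydrogen in its place gives a 14-fold higher number from compound 2 to compound 3 (1.15 log units; beyond the scatter), the first single-change step and a large one. With the chloromethyl-bearing benzyl group and the other chloro group unchanged, this step isolates the loss to this one position on the six-membered aromatic ring with 2 nitrogen, so the position cannot be treated as indifferent to substitution. Nothing at hand explains the size of this step.

As far as these compounds go, whether the higher number reflects the loss of chloro specifically, or whether other groups on the same carbon can stand in for it, remains open; an amine, a methoxy group, a methyl group or a fluoro group there would separate these readings. Also open, from the compounds shown here alone, is whether a step of this size persists when the chloromethyl group on the benzyl ring gives way to another group, such as a hydroxymethyl group or a plain methyl group.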